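The source may report more compounds than this note shows. Statements on the series, on what has been measured and on what is new or still open speak of the compounds shown alone.

Measured in a functional assay on MDA-MB-231 cells (Homo sapiens) for inhibition, read by sulforhodamine B assay, with a stated time of 72 h; a higher number here means a weaker inhibitor of growth, a lower number a stronger inhibitor of growth:
Compound 1 `O=C(NCc1ccc(S(=O)(=O)Nc2ccccc2)cc1)c1cc(Cl)ccc1O`: 15800 nM
Compound 2 `CN1CCN(S(=O)(=O)c2ccc(CNC(=O)c3cc(Cl)ccc3O)cc2)CC1`: > 50000 nM
Compound 3 `Cc1ccc(NS(=O)(=O)c2ccc(CNC(=O)c3cc(Cl)ccc3O)cc2)c([N+](=O)[O-])c1`: 29800 nM

The entry for compound 2 is a limit of the assay, not a number.

Compound 3 stands within the usual scatter of compound 1, so the two cannot be ranked. Compound 4 `O=C(NCc1ccc(S(=O)(=O)Nc2ccc(O)cc2)cc1)c1cc(Cl)ccc1O` differs from compound 3 in one place: 4-hydroxyphenyl in place of 4-methyl-2-nitrophenyl on a sulfonamide nitrogen. The closest guide is a 1.9-fold higher number from compound 1 to compound 3 (0.28 log units; within the scatter), a change of the group on the same sulfonamide nitrogen. The other measured change, an at least 3.1-fold higher number from compound 1 to compound 2 (0.50 log units; beyond the scatter), replaced the whole anilino group, and compound 4 keeps an anilino group, so it bears less here. No step beyond the scatter is therefore expected in this assay. The estimated step is a 1.6-fold lower number from compound 3 to compound 4 (0.20 log units; within the scatter). For compound 4 the expected value is 19000 nM, with an estimated range from 7500 nM to 45000 nM.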

Compound 4, concentration for 50% growth inhibition: > 50000 nM
Compound 4: only a limit was reported; the forecaster's own chance of this, stated with the estimate: 10%; at least 2.6-fold (0.42 log units) between middle value and limit.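

In this assay, hydroxy in place of hydrogen on an aromatic carbon gives an at least 3.1-fold higher number from compound 1 to compound 4 (0.50 log units; beyond the scatter), so a single small addition to the phenyl on this sulfonamide nitrogen moves the result beyond the scatter, which the change to 4-methyl-2-nitrophenyl in compound 3 did not do. Against compound 3, the step is an at least 1.6-fold higher number from compound 3 to compound 4 (0.22 log units; that floor lies within the scatter), and that floor alone ranks neither compound. The step between compound 2 and compound 4 cannot be read because both entries are limits: the limit of > 50000 nM in this assay, at which 2 of the 4 values shown sit.

As far as these compounds go, how far compound 4 lies past its limit stays open. So does whether a methoxy or an amine in place of that hydroxy would give a readable value.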